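Dropping the Ring Methyl from a Cathepsin S Nitrile

The source may hold more compounds than are shown below. What is called first, only, known or untested is meant among the compounds shown, and "the series" means these compounds.

Measured compounds:
compound 1 `CC1CCC(C[C@H](CC(=O)N2CCOCC2)C(=O)N[C@]2(C#N)CCN(C3CCCCC3)C2)CC1` gives 13.8 nM
compound 2 `N#C[C@H](CCc1ccccc1)NC(=O)[C@@H](CC(=O)N1CCOCC1)CC1CCCCC1` gives 25 nM
compound 3 `CN1CCC(C#N)(NC(=O)[C@@H](CC(=O)N2CCOCC2)CC2CCCCC2)CC1` gives 177 nM

All three were tested in an assay on isolated protein for inhibition of cathepsin S (Homo sapiens); on this read-out higher numbers stand for weaker binding and lower numbers for tighter binding. Compound 1 has the lowest number of the three; the gap to compound 2 lies within the usual scatter, while compound 3 sits clearly beyond it with a markedly higher number.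

Compound 4 `N#C[C@@]1(NC(=O)[C@@H](CC(=O)N2CCOCC2)CC2CCCCC2)CCN(C2CCCCC2)C1` differs from compound 1 by hydrogen in place of methyl on a saturated ring carbon, so that the (4-methylcyclohexyl)methyl group becomes cyclohexylmethyl. For the measured compounds named here, no pair of measured compounds isolates this change: compound 2 and compound 3 both carry the plain cyclohexylmethyl group, but each also differs from compound 1 in the nitrile-bearing part, so their values say nothing clean about the methyl alone. A single ring methyl is a small change, and the expected step from compound 1 to compound 4 is a 1.6-fold higher number from compound 1 to compound 4 (0.20 log units; within the scatter), toward a slightly higher number but not beyond the scatter. Compound 4 is therefore estimated at 22 nM, with a range from 8 nM to 60 nM.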

Compound 4, dissociation constant: 17.8 nM
Compound 4: middle estimate off by 1.2-fold (0.09 log units), on the high side, and the stated range covers the measured number.
By their numbers in this assay, from the lowest: compounds 1, 4 and 2 (each within the scatter of the next); then compound 3.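

In this assay, the methyl on this saturated ring carbon, three ring bonds from the ring atom that bears the large group, can now be read on its own: the step is a 1.3-fold higher number from compound 1 to compound 4 (0.11 log units; within the scatter), so on the shared core the (4-methylcyclohexyl)methyl and cyclohexylmethyl groups cannot be told apart. Compound 2 and compound 3 could not show this, since each also differs from compound 1 in the nitrile-bearing part. Nothing given here accounts for this result.

From the compounds shown here alone, whether a hydroxyl group, an amine or a tert-butyl group on this ring carbon would also stay within the scatter of compound 1 remains open. So does whether a methyl on the same ring carbon would leave the numbers of compound 2 and compound 3 as little changed.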